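The source may report more compounds than this note shows. Statements on the series, on what has been measured and on what is new or still open speak of the compounds shown alone.

In a functional assay on MDA-MB-231 cells (Homo sapiens) for antiproliferative activity, read by sulforhodamine B assay, with a stated time of 72 h (on this read-out higher numbers stand for weaker inhibition and lower numbers for stronger inhibition), compound 1 `COc1ccc2nc(Cl)c(/C=C\c3ccc(C(F)(F)F)cc3)cc2c1` gives 22800 nM. Compound 2 `COc1ccc2nc(Cl)c(/C=C/c3ccc(C(F)(F)F)cc3)cc2c1` gives 48800 nM, and compound 3 `COc1ccc2nc(Cl)c(/C=C\c3ccc(F)cc3)cc2c1` gives 11400 nM. Compound 1 thus stands within the scatter of one neighbour and just beyond it from the other. The first measured comparison is a 2.1-fold higher number from compound 1 to compound 2 (0.33 log units; beyond the scatter), which goes with the fact that compounds 1 and 2 differ only in the configuration as drawn. The second, fluoro in place of trifluoromethyl on an aromatic carbon, is a 2.0-fold lower number from compound 1 to compound 3 (0.30 log units; within the scatter).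

Compound 4 `COc1ccc2nc(Cl)c(/C=C\c3ccc(C(F)(F)F)cc3C(F)(F)F)cc2c1` keeps the double bond drawn Z and carries one further group: trifluoromethyl in place of hydrogen on an aromatic carbon. This is trifluoromethyl in place of hydrogen on an aromatic carbon, ortho to a large group and meta to a trifluoromethyl group. Among the compounds with values here, no measured step makes this exact change. The closest guide is the substituent exchange in compound 3, a 2.0-fold lower number from compound 1 to compound 3 (0.30 log units; within the scatter), so no shift beyond the scatter is expected in this assay. The expected step is a 1.1-fold higher number from compound 1 to compound 4 (0.02 log units; within the scatter). The estimate for compound 4 is 24000 nM, with an expected range from 9000 nM to 60000 nM.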

Compound 4, half-maximal inhibitory concentration: > 50000 nM
Compound 4 was reported as a limit; the forecaster's own chance of this, stated with the estimate: 10%; at least 2.0-fold (0.31 log units) between middle value and limit.
By their numbers in this assay, from the lowest: compounds 3 and 1 (each within the scatter of the next); then compound 2. At a limit, above all of these: compound 4.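

In this assay compound 4 is recorded only as a limit, > 50000 nM. Within the data shown here, the earlier compounds changed the configuration of the double bond or exchanged one substituent for another, whereas this is the first change that fills a hydrogen-bearing carbon of the aromatic ring, at the place ortho to a large group and meta to a trifluoromethyl group. On these data alone, the step, an at least 2.1-fold higher number from compound 1 to compound 4 (0.34 log units; beyond the scatter), goes towards weaker inhibition and lies beyond the scatter, and its full size stays unknown.

The compounds shown leave open whether this result belongs to the place or to trifluoromethyl itself, as no other group stands there. As far as these compounds go, an amine or a methyl group at the same carbon would separate the two, and the same addition on the E double bond of compound 2 remains untested here.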